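Adding a Hydroxy Group to Compound 1

The source may hold more compounds than are shown below. What is called first, only, known or untested is meant among the compounds shown, and "the series" means these compounds.

Compound 1 (`COc1ccc(-c2c(Nc3cc(OC)c(OC)c(OC)c3)c3ccccc3oc2=O)cc1`) and compound 2 (`COc1ccc(-c2c(Nc3cccc(C(F)(F)F)c3)c3ccccc3oc2=O)cc1`) share a core and differ in the substituents on the aniline-type ring attached to it. In a functional assay on HepG2 cells (Homo sapiens) for antiproliferative activity, read by MTT assay, with a stated time of 48 h (on this read-out lower numbers stand for stronger inhibition and higher numbers for weaker inhibition), compound 1 gives 77300 nM and compound 2 gives 66400 nM as half-maximal inhibitory concentrations. These two values lie within the usual scatter of each other, so compound 1 cannot be separated from compound 2 on these numbers. Compound 3 (`COc1ccc(-c2c(Nc3cc(OC)c(OC)c(OC)c3)c3ccc(O)cc3oc2=O)cc1`) keeps everything in compound 1 but has hydroxy in place of hydrogen on an aromatic carbon of the shared core. Within the data shown here, no measured pair shows what this exchange does here, so no large shift is assumed. The estimated step of a 1.7-fold lower number from compound 1 to compound 3 (0.23 log units; within the scatter) is expected to stay within the scatter, leaning slightly towards stronger inhibition. In this assay compound 3 is expected at 45000 nM (estimated range 15000 nM to 110000 nM).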

Compound 3, half-maximal inhibitory concentration: 49700 nM
Beside the measured number, compound 3's estimate is 1.1-fold (0.04 log units) below it; low and high end bracket the measured number.
By their numbers in this assay, from the lowest: compounds 3, 2 and 1 (each within the scatter of the next).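

In this assay, the step from hydrogen to hydroxy on this aromatic carbon of the shared core is a 1.6-fold lower number from compound 1 to compound 3 (0.19 log units; within the scatter), so at this position the added hydroxy brings no shift that can be told from the scatter. Among these compounds, the earlier pair differed only on the aniline-type ring, and this step is the only reading here of a change on the shared core, which shows that this position accepts a hydroxy without a clear loss or gain in this cell read-out. No measurement at hand bears on this result.

Still open, going by these compounds, is whether an amine or a carboxylic acid in place of the hydroxy at this same aromatic carbon would move the number beyond the scatter. Also open, on these data alone, is whether hydroxy at this position would give a similar step on compound 2, which carries trifluoromethyl on the aniline-type ring.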